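The source may hold more compounds than are shown below. What is called first, only, known or untested is meant among the compounds shown, and "the series" means these compounds.

The measured compounds:

Compound 1 `CN(C[C@H]1Cc2c(cccc2N2CCN(C3CC3)CC2)CN1)[C@H]1CCCc2cccnc21` — in a functional assay on CCRF-CEM cells for agonist activity at C-X-C chemokine receptor type 4 (Homo sapiens), read by calcium flux, with a stated time of 25 min (on this read-out lower numbers stand for an effect already at smaller amounts and higher numbers for an effect only at larger amounts of compound), compound 1 gives > 30000 nM, which is a limit of the assay and not a number.
Compound 2 `CC(C)N1CCN(c2cccc3c2C[C@H](CN(C)[C@H]2CCCc4cccnc42)NC3)CC1` — in this assay compound 2 gives > 30000 nM, again a limit.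
Compound 3 `CN(C[C@H]1Cc2c(cccc2N2CCN(Cc3ccccn3)CC2)CN1)[C@H]1CCCc2cccnc21` — in this assay compound 3 gives > 30000 nM, also a limit.

Compound 3 therefore stands at the limit, as do the two other measured compounds, all three values sitting at the limit of > 30000 nM in this assay, at which 3 of the 3 values shown sit. Among the measured compounds shown here, the steps that bear on the same ring nitrogen, from compound 1 to compound 3 a step that the two limits leave unreadable from compound 1 to compound 3 and from compound 2 to compound 3 a step that the two limits leave unreadable from compound 2 to compound 3, cannot be read in size, and the step from compound 1 to compound 2 a step that the two limits leave unreadable from compound 1 to compound 2 is likewise unreadable.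

Compound 4 `CN(C[C@H]1Cc2c(cccc2N2CCN(c3ncccn3)CC2)CN1)[C@H]1CCCc2cccnc21` differs from compound 3 by pyrimidin-2-yl in place of (pyridin-2-yl)methyl on an amine nitrogen in a ring. For the measured compounds named here, no measured step involves a pyrimidin-2-yl group, and the steps at this position give no readable size, so no direction can be taken from them. Compound 4 is expected to give about 40000 nM, within 15000 nM to 200000 nM, most probably once more as a limit. The step from compound 3 to compound 4 is therefore estimated as a step that the limit leaves unreadable from compound 3 to compound 4, not readable beyond the scatter.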

Compound 4, half-maximal effective concentration: > 30000 nM
Compound 4: no number, only a limit; the forecaster's own chance of this, stated with the estimate: 85%; the middle value does not contradict the limit.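

In this assay compound 4 gives > 30000 nM, which is a limit and not a number, so its steps from compound 1, compound 2 and compound 3 cannot be read. The compounds shown leave open how any of these groups on the ring nitrogen compare in size of effect, as all values sit at one limit: the limit of > 30000 nM in this assay, at which 4 of the 4 values shown sit.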